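The source may hold more compounds than are shown below. What is called first, only, known or untested is meant among the compounds shown, and "the series" means these compounds.

Compound 1 `O=C(/C=C/c1ccc2c(c1)B(O)OC2)c1ccco1`: > 10 ug/mL
Compound 2 `COc1cccc(C(=O)/C=C/c2ccccc2)c1`: 5.7 ug/mL
Compound 3 `COc1cccc(C(=O)CCc2ccc3c(c2)B(O)OC3)c1`: > 10 ug/mL

In an ADME assay on L929 cells (Mus musculus) for cytotoxicity, read by resazurin assay, with a stated time of 72 h (on this read-out lower numbers stand for stronger inhibition and higher numbers for weaker inhibition), compound 1 gives > 10 ug/mL, which is a limit of the assay and not a number. Compound 3 likewise gives > 10 ug/mL, again a limit. Within the data shown here, compound 2 gives 5.7 ug/mL, the one numerical value shown. Compound 1 thus stands at the limit of > 10 ug/mL in this assay, at which 2 of the 3 values shown sit, with no measured number to place it against the others. Compound 4 `Cc1ccc(C(=O)/C=C/c2ccc3c(c2)B(O)OC3)cc1` differs from compound 1 by 4-methylphenyl in place of furan-2-yl on a carbonyl carbon. Among the measured compounds shown here, no measured pair shows this change, and in this assay the expected step is a step that the limit leaves unreadable from compound 1 to compound 4, none beyond the usual scatter. Compound 4 is therefore expected to give about 12 ug/mL, between 5 ug/mL and 30 ug/mL, with a fair chance that only a limit is reported once more.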

Compound 4, half-maximal inhibitory concentration: > 10 ug/mL
Compound 4 ended at the assay's limit; the forecaster's own chance of this, stated with the estimate: 60%; the middle value is on the limit's open side.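

In this assay, among these compounds, compound 1 and compound 4 both end at a limit of the assay and not at a number, and no step between them can be read. The compounds shown leave open whether 4-methylphenyl in place of furan-2-yl on a carbonyl carbon changes the value at all.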